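The source may report more compounds than this note shows. Statements on the series, on what has been measured and on what is new or still open speak of the compounds shown alone.

Measured so far in an ADME assay on L6 cells (Rattus norvegicus) for cytotoxicity, with a stated time of 72 h; on this read-out higher numbers stand for weaker inhibition and lower numbers for stronger inhibition:
- compound 1 `O=C(CN1CCCCC1)OC1CC2(N3CCCCC3)CC(c3ccccc3)C1C(c1ccccc1)C2` gives 60400 nM
- compound 2 `O=C(CN1CCCC1)OC1CC2(N3CCCC3)CC(c3ccccc3)C1C(c1ccccc1)C2` gives 42900 nM
- compound 3 `OC1CC2(N3CCCCC3)CC(c3ccccc3)C1C(c1ccccc1)C2` gives 37300 nM

Compound 3 carries a free hydroxy group, and its gaps to compound 1 and to compound 2 both lie within the usual scatter, so it cannot be set apart from either of them. Compound 4 `O=C(CN1CCCC1)OC1CC2(N3CCCCC3)CC(c3ccccc3)C1C(c1ccccc1)C2` has not been measured yet. It is compound 3 with ((pyrrolidin-1-yl)methyl)carbonyl in place of hydrogen on an oxygen on a saturated carbon, a difference counted as ((pyrrolidin-1-yl)methyl)carbonyl in place of hydrogen on an oxygen on a saturated carbon in full.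

Going by the values given here, one measured step bears closely on this. The step of a 1.6-fold lower number from compound 1 to compound 3 (0.21 log units; within the scatter) removes the related ((piperidin-1-yl)methyl)carbonyl group from the same oxygen. Read backwards, it suggests that putting such a group on the hydroxy moves the number little. Though it differs from compound 4 elsewhere, compound 2 also carries the incoming group, and as a second reference point compound 2 gives 42900 nM in this assay. No change beyond the scatter is therefore expected, and the estimated step is a 1.3-fold higher number from compound 3 to compound 4 (0.13 log units; within the scatter) in size. Compound 4 is estimated at 50000 nM with an expected range from 29000 nM to 85000 nM in this read-out.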

Compound 4, half-maximal inhibitory concentration: 16400 nM
Beside the measured number, compound 4's estimate is 3.0-fold (0.48 log units) above it; measured number outside the range, below it.
By their numbers in this assay, from the lowest: compound 4; then compounds 3, 2 and 1 (each within the scatter of the next).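

In this assay, the hydroxy on the shared core turns out to be a position where the attached group matters: with ((pyrrolidin-1-yl)methyl)carbonyl on that oxygen there is a 2.3-fold lower number from compound 3 to compound 4 (0.36 log units; beyond the scatter), whereas the related piperidine-bearing group showed only a 1.6-fold lower number from compound 1 to compound 3 (0.21 log units; within the scatter). Changing either ring alone also has a measurable effect, since piperidin-1-yl in place of pyrrolidin-1-yl on a saturated ring carbon gives a 2.6-fold lower number from compound 2 to compound 4 (0.42 log units; beyond the scatter), and pyrrolidin-1-yl in place of piperidin-1-yl on a saturated chain carbon bound to a carbonyl carbon gives a 3.7-fold lower number from compound 1 to compound 4 (0.57 log units; beyond the scatter). Compound 4 is the only compound shown that pairs the piperidin-1-yl ring on the core with the pyrrolidin-1-yl ring on the side chain, and all three of its steps lie beyond the scatter, though each is modest.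

Still open, as far as these compounds go, is whether this effect is specific to the pyrrolidin-1-yl ring, or would also appear with a morpholin-4-yl ring, an open-chain dimethylamino group, or a longer chain between the carbonyl and the ring. The compounds shown offer no measured evidence for why these changes lower the number.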